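The source may hold more compounds than are shown below. What is called first, only, known or untested is meant among the compounds shown, and "the series" means these compounds.

Measured in a functional assay on HepG2 cells (Homo sapiens) for cytotoxicity, read by MTT assay, with a stated time of 72 h; a lower number here means a stronger inhibitor, a higher number a weaker inhibitor:
- Compound 1 `Cc1ccc(-c2nc3cc(NC(=O)CCN4CCN(C)CC4)ccc3[nH]2)cc1`: > 50000 nM (a limit)
- Compound 2 `Cc1ccc(-c2nc3cc(NC(=O)CCN4CCCCC4)ccc3[nH]2)cc1`: 11900 nM

Not yet measured:
- Compound 3 `CCN1CCN(CC(=O)Nc2ccc3[nH]c(-c4ccc(C)cc4)nc3c2)CC1`

Among the compounds with values here, compound 2, at 11900 nM, holds the only actual number in this assay. Compound 1 reads > 50000 nM, which is a limit of the assay and not a number.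

The step to compound 3 is 4-ethylpiperazin-1-yl in place of (piperidin-1-yl)methyl on a saturated chain carbon bound to a carbonyl carbon. In words, 4-ethylpiperazin-1-yl stands in place of (piperidin-1-yl)methyl on a saturated chain carbon bound to a carbonyl carbon.

Within the data shown here, one measured step bears on this change: an at least 4.2-fold lower number from compound 1 to compound 2 (0.62 log units; beyond the scatter). It put piperidin-1-yl in place of 4-methylpiperazin-1-yl. Compound 3 carries a piperazin-1-yl group again, so a step of similar size in the opposite direction, toward a higher number, is expected. This expectation rests on an at least 4.2-fold lower number from compound 1 to compound 2 (0.62 log units; beyond the scatter), and its size is uncertain since that step is bounded on one side only. Among the measured compounds shown here, no measured step isolates the chain part of the change.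

The expected change is a 2.5-fold higher number from compound 2 to compound 3 (0.40 log units; beyond the scatter). For compound 3 the estimate is 30000 nM, with an expected range from 10000 nM to 80000 nM.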

Compound 3, half-maximal inhibitory concentration: 31900 nM
Beside the measured number, compound 3's estimate is 1.1-fold (0.03 log units) below it, within the range that was stated.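

In this assay, 4-ethylpiperazin-1-yl in place of (piperidin-1-yl)methyl on a saturated chain carbon bound to a carbonyl carbon gives a 2.7-fold higher number from compound 2 to compound 3 (0.43 log units; beyond the scatter). Among the compounds shown, both that carry a piperazin-1-yl group therefore read higher than compound 2, none goes against this, and compound 3 supplies the only actual number for such a group. Compound 1 stands at > 50000 nM, which is a limit of the assay and not a number, so the comparison with it reads only as an at least 1.5-fold lower number from compound 1 to compound 3 (0.19 log units; that floor lies within the scatter), and it stays bounded on one side: the limit of > 50000 nM in this assay, at which 1 of the 3 values shown sits.

Compound 3 differs from compound 2 in both the ring and the chain at once, so the compounds shown do not tell how much of the step belongs to each part, nor whether the ethyl group on the ring matters. Going by these compounds, how a piperidin-1-yl group on the chain of compound 3, or a morpholin-4-yl group at this place, would read in this assay also remains open.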